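The compounds below may be only part of what the source reports. "The series", "measured", "known", "first", "only" and "open" are said of these compounds alone.

Working notes on the series.

Compound 1 `N#CC1=C(N)N(c2ccc(S(N)(=O)=O)cc2)C2=C(C(=O)CCC2)C1c1ccccc1` and compound 2 `N#CC1=C(N)N(c2ccc(S(N)(=O)=O)cc2)C2=C(C(=O)CCC2)C1c1ccc([N+](=O)[O-])cc1` share one core and differ only at the saturated ring carbon. In a functional assay on Ehrlich cells (Mus musculus) for antiproliferative activity, read by trypan blue exclusion, with a stated time of 2 h, tested at 10 ug/mL (a higher number here means a stronger effect of the compound at the concentration tested, a lower number a weaker effect), compound 1 gives 10%. In this assay compound 2 gives 85%. Within the data shown here, the single measured step, a number 75 percentage points higher from compound 1 to compound 2 (beyond the scatter), is the whole of what the two numbers show, and compound 2 stands highest of the two, with compound 1 as the only neighbour and well beyond the scatter below it.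

Compound 3 `COc1ccc(C2C(C#N)=C(N)N(c3ccc(S(N)(=O)=O)cc3)C3=C2C(=O)CCC3)c2ccccc12` is not yet measured in this assay. Its difference from compound 2 is 4-methoxynaphthalen-1-yl in place of 4-nitrophenyl on a saturated ring carbon. Among the measured compounds shown here, the one measured step that bears on this change is the step from compound 1 to compound 2, because it concerned the same saturated ring carbon and the same nitro group that now leaves a number 75 percentage points higher from compound 1 to compound 2 (beyond the scatter). For the measured compounds named here, no measured step shows what a 4-methoxynaphthalen-1-yl brings, so the entering group is an unknown here. The step to compound 3 is therefore expected to run downward, a number 50 percentage points lower from compound 2 to compound 3 (beyond the scatter), with a wide band. For compound 3 the expected value in this assay is 35%, estimated between 10% and 70%.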

Compound 3, a percentage reported as activity, at one concentration (the size of the read-out at that concentration, not a potency): 10%
For compound 3 the middle estimate is 25 percentage points above the measured one, and the stated range covers the measured number.
By their numbers in this assay, from the lowest: compounds 1 and 3 (each within the scatter of the next); then compound 2.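

The change shows that the high read-out at this saturated ring carbon does not survive the exchange of 4-nitrophenyl for 4-methoxynaphthalen-1-yl: in this assay it is a number 75 percentage points lower from compound 2 to compound 3 (beyond the scatter), as large as the gain the nitro group brought in the first step. Set against the phenyl group, the same entering group gives no change at the digits printed from compound 1 to compound 3 (within the scatter), so among these three compounds only the 4-nitrophenyl group of compound 2 stands apart, and a second aromatic ring with a methoxy group does not reproduce its effect. Nothing available bears on why these groups differ so widely in this read-out.

The exchange alters several features at once, since the nitro group leaves while a second aromatic ring and a methoxy group enter, so the three compounds cannot assign the loss to any one of them. Also open, as far as these compounds go, is whether the effect is particular to nitro, or would persist with an amine or a carboxylic acid in its place on the phenyl ring, and how a naphthalenyl group without the methoxy group would read.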